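Working notes: methylamino to morpholin-4-yl on the carbonyl

The source may hold more compounds than are shown below. What is called first, only, known or untested is meant among the compounds shown, and "the series" means these compounds.

Measured in a functional assay on KB cells (Homo sapiens) for inhibition, read by sulforhodamine B assay, with a stated time of 72 h; a higher number here means a weaker inhibitor of growth, a lower number a stronger inhibitor of growth:
- compound 1 `CCOC(=O)/C=C/c1ccncc1-c1ccc2c(cnn2C)c1`: > 10000 nM
- compound 2 `CNC(=O)/C=C/c1ccncc1-c1ccc2cc[nH]c2c1`: > 10000 nM
- compound 3 `CCOC(=O)/C=C/c1ccncc1-c1ccc2[nH]ccc2c1`: > 10000 nM

Each of these three entries is a limit of the assay and not a number. Within the data shown here, the series so far gives one reading: the limit of > 10000 nM in this assay, at which 3 of the 3 values shown sit. Compound 2 therefore has no numeric value in this assay, and the two other compounds offer no number to rank it against.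

The next compound is compound 4 `O=C(/C=C/c1ccncc1-c1ccc2cc[nH]c2c1)N1CCOCC1`. It differs from compound 2 in one place, with morpholin-4-yl in place of methylamino on a carbonyl carbon. The same difference, cut one bond further out, reads methylcarbamoyl to (morpholin-4-yl)carbonyl.

Among the measured compounds shown here, no pair of measured compounds shows the size of a change like this one. The expectation rests only on (the limit of > 10000 nM in this assay, at which 3 of the 3 values shown sit). No shift beyond the usual scatter is expected in this assay, and no direction is favoured. The expected change is a step that the limit leaves unreadable from compound 2 to compound 4. Another report as a limit is the likeliest outcome. For compound 4 the estimated value is 12000 nM, with an expected range from 5000 nM to 30000 nM.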

Compound 4, concentration for 50% growth inhibition: > 10000 nM
Compound 4 was reported as a limit; the forecaster's own chance of this, stated with the estimate: 85%; the middle value lies beyond the limit too.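

In this assay compound 2 and compound 4 are both reported as limits and not as numbers, so the step from methylamino to morpholin-4-yl on the carbonyl carbon cannot be read. The compounds shown leave open whether any of these structures gives a readable growth inhibition, and how far a change on the carbonyl would move it: the limit of > 10000 nM in this assay, at which 4 of the 4 values shown sit.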